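Fluoro to Trifluoromethyl at Two Ring Positions

The source may report more compounds than this note shows. Statements on the series, on what has been measured and on what is new or still open speak of the compounds shown alone.

Three compounds have so far been examined in a functional assay on RAW264.7 cells (Mus musculus) for inhibition, read by fluorescence, with stated times of 1 h, 24 h and 30 min; a lower number here means a stronger inhibitor, a higher number a weaker inhibitor. Compound 1 `O=C(/C=C/c1ccccc1F)c1ccccc1` gives > 10000 nM, which is a limit of the assay and not a number. Compound 2 `O=C(/C=C/c1ccc(F)cc1)c1ccccc1` likewise gives > 10000 nM, again a limit. Compound 3 `O=C(/C=C/c1ccccc1C(F)(F)F)c1ccccc1` gives > 10000 nM, also a limit. Compound 1 and compound 2 are built from the same atoms joined differently; the difference between the two cores is not broken down here. From compound 1 to compound 3 the change is trifluoromethyl in place of fluoro on an aromatic carbon, and the resulting step that the two limits leave unreadable from compound 1 to compound 3 stays unreadable because of the limit of > 10000 nM in this assay, at which 3 of the 3 values shown sit. Compound 4 `O=C(/C=C/c1ccc(C(F)(F)F)cc1)c1ccccc1` has not yet been measured. It differs from compound 2 by trifluoromethyl in place of fluoro on an aromatic carbon, the same kind of change as that from compound 1 to compound 3, though here the group sits para to a large group rather than ortho to it. Compound 4 is expected to give 15000 nM in this assay, very likely as a limit once more, with a plausible range from 5000 nM to 50000 nM. The expected step that the limit leaves unreadable from compound 2 to compound 4 rests on the unreadable a step that the two limits leave unreadable from compound 1 to compound 3.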

Compound 4, half-maximal inhibitory concentration: > 10000 nM
Compound 4 was reported as a limit; the forecaster's own chance of this, stated with the estimate: 85%; the middle value does not contradict the limit.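

Neither compound 2 nor compound 4 gives a number in this assay, so trifluoromethyl in place of fluoro yields no readable step from compound 2 to compound 4: the limit of > 10000 nM in this assay, at which 4 of the 4 values shown sit. The compounds shown leave open how strongly any of the four inhibits, and whether trifluoromethyl in place of fluoro changes inhibition at all.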